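Replacing butoxy with propyl on a shared amide core

This account rests on a few compounds, and the source may have more. Where it says the series, first, only, none or still open, it means among the compounds named here.

Compound 2 `CCCCOc1cccc(C(=O)Nc2nn[nH]n2)n1` gives 8% in a functional assay on the whole organism for inhibition, with Rattus norvegicus as the target, at a dose of 10 mg/kg by the oral route (a lower number here means a weaker effect, a higher number a stronger effect of the compound at the dose given), the second highest of the three numbers shown. Its nearest neighbour, compound 1 `O=C(Nc1nn[nH]n1)c1cccnc1`, gives 3% in this assay, a gap that lies within the scatter. Compound 3 `O=C(Nc1nn[nH]n1)c1ncccc1Cl` gives 22% in this assay, and its gap from compound 2 lies beyond the scatter. Among the measured compounds shown here, no pair of measured compounds differs in one place, so the move to compound 4 `CCCc1cccc(C(=O)Nc2nn[nH]n2)n1` rests on the structural change alone: propyl in place of butoxy on an aromatic carbon. With every measured number low and nothing shown to argue for a rise or a fall, no step in this assay beyond the scatter is expected in either direction. Compound 4 is thus expected at 9%, between 0% and 22%, a step of a number 1 percentage points higher from compound 2 to compound 4 (within the scatter) expected to stay within the scatter.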

Compound 4, a percentage reported as inhibition, in the whole organism at one dose (the size of the read-out at that dose, not a potency): 38%
Estimate against measurement, compound 4: 29 percentage points below, outside the stated range (above it).
By their numbers in this assay, from the lowest: compounds 1 and 2 (each within the scatter of the next); then compound 3; then compound 4.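

In this assay, among the compounds shown here, the change to propyl in place of butoxy, on the aromatic carbon next to the ring nitrogen, gives a number 30 percentage points higher from compound 2 to compound 4 (beyond the scatter) and is the first single change that can be read. It shows that the read-out at this dose responds to what this position carries, even though the two groups differ only by the ether oxygen and the chain length. No measurement shown gives a reason for the rise.

The compounds shown leave open whether the oxygen or the chain length accounts for the step. A butyl or a propoxy group on the same carbon would separate the two.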